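Swapping a carboxyethyl for a plain butyl chain

The source may hold more compounds than are shown below. What is called first, only, known or untested is meant among the compounds shown, and "the series" means these compounds.

Measured compounds:
- compound 1, `OCCNc1nnc2nncn2n1`, 3310 nM
- compound 2, `CC(Nc1nnc2nncn2n1)C(=O)O`, 82200 nM
- compound 3, `OCC(CO)(CO)Nc1nnc2nncn2n1`, 12400 nM

These three compounds share one core and differ only in the group attached to a nitrogen on an aromatic ring. In a functional assay on BeWo cells (Homo sapiens) for inhibition, read by MTT assay, with a stated time of 72 h (on this read-out higher numbers stand for weaker inhibition and lower numbers for stronger inhibition), compound 1 gives 3310 nM. Compound 2 stands highest of the three, giving 82200 nM, while compound 3 gives 12400 nM and sits between the two. Among the measured compounds shown here, the one directly comparable step, a 25-fold higher number from compound 1 to compound 2 (1.40 log units; beyond the scatter), shows that introducing the acid-bearing group made the number much larger.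

Compound 4, `CCCCNc1nnc2nncn2n1`, has not yet been measured. It differs from compound 2 as follows: butyl in place of 1-carboxyethyl on a nitrogen on an aromatic ring. The change removes the carboxyethyl whose arrival in the step from compound 1 to compound 2 raised the number so sharply, and replaces it with a simple chain carrying no donors or acceptors. For the measured compounds named here, no measured compound carries a plain alkyl chain, so the expectation rests on that one step alone. Because a 25-fold higher number from compound 1 to compound 2 (1.40 log units; beyond the scatter) was large and upward, the reverse kind of change is expected to bring the number down, and the estimated step is a 21-fold lower number from compound 2 to compound 4 (1.31 log units; beyond the scatter). Compound 4 is therefore expected to give about 4000 nM in this assay, within a range from 1000 nM to 20000 nM.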

Compound 4, half-maximal inhibitory concentration: 8640 nM
Estimate against measurement, compound 4: 2.2-fold (0.33 log units) below, and the stated range covers the measured number.
By their numbers in this assay, from the lowest: compound 1; then compounds 4 and 3 (each within the scatter of the next); then compound 2.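

Butyl in place of 1-carboxyethyl gives a 9.5-fold lower number from compound 2 to compound 4 (0.98 log units; beyond the scatter) in this assay, so a chain with no hydrogen-bond donor or acceptor gives a much lower number at this nitrogen than the 1-carboxyethyl group does. The hydroxy group of compound 1 also matters, though less: ethyl in place of hydroxy gives a 2.6-fold higher number from compound 1 to compound 4 (0.42 log units; beyond the scatter), which leaves compound 1 with the lower number of that pair. No measurement in hand explains either step.

Going by these compounds, it stays open whether a longer chain or a chain ending in an amine could bring the number below that of compound 1. A carboxylic acid on an unbranched chain would help show whether the acid or the methyl branch of the 1-carboxyethyl group accounts for the high number of compound 2.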